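The source may report more compounds than this note shows. Statements on the series, on what has been measured and on what is new or still open speak of the compounds shown alone.

Among the compounds with values here, in a functional assay on cells (Cancer cell lines, Homo sapiens) for inhibition (a lower number here means a stronger inhibitor of growth, a higher number a weaker inhibitor of growth), compound 1 `N=C(N)N/N=C/c1c(-c2cc(Cl)sc2Cl)nc2n1CCS2` gives 10000 nM and compound 2 `Cc1cc(-c2nc3n(c2/C=N/NC(=N)N)CCS3)c(C)s1` gives 17400 nM, so compound 2 stands within the scatter of the only other measured compound. Compound 3 `N=C(N)N/N=C/c1c(-c2cccs2)nc2n1CCS2` differs from compound 2 by thiophen-2-yl in place of 2,5-dimethylthiophen-3-yl on an aromatic carbon. Within the data shown here, the only measured step that bears on this change, a 1.7-fold higher number from compound 1 to compound 2 (0.24 log units; within the scatter), also exchanged a thiophene-bearing group on an aromatic carbon, and it stayed within the scatter. No shift beyond the scatter is therefore expected in this assay. The expected step is a 1.3-fold lower number from compound 2 to compound 3 (0.13 log units; within the scatter). Compound 3 is estimated at 13000 nM, with an expected range of 5000 nM to 35000 nM.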

Compound 3, concentration for 50% growth inhibition: 22900 nM
The estimate for compound 3 lay 1.8-fold (0.25 log units) below the measured number; measured number inside the range.
By their numbers in this assay, from the lowest: compounds 1, 2 and 3 (each within the scatter of the next, the first and the last beyond it).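

In this assay, within the data shown here, thiophen-2-yl stays within the scatter of 2,5-dimethylthiophen-3-yl, with a 1.3-fold higher number from compound 2 to compound 3 (0.12 log units; within the scatter) as the step, whereas a 2.3-fold higher number from compound 1 to compound 3 (0.36 log units; beyond the scatter) is the first step at this position to pass beyond the scatter, though only modestly, with thiophen-2-yl replacing 2,5-dichlorothiophen-3-yl. This aromatic carbon therefore responds to a thiophene exchange, but only between these two groups. No measurement available here accounts for this difference. The compounds shown carry only thiophene groups at this position, so the effect of a phenyl ring, an amine or a carboxylic acid there remains open.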